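Swapping the aryl group on the shared core

A few compounds are considered here, and "the series" means these few. Any claim that something is new, unique, unknown or untested is made for them only; others in the source may bear on it.

Measured compounds so far:
compound 1, `Brc1cn2ccnc2c(-c2ccc3ncn(C4CCCCC4)c3c2)n1`, 6.6%
compound 2, `c1cn2cc(-c3ccsc3)nc(-c3ccc4ncn(C5CCCCC5)c4c3)c2n1`, 1.51%

Both compounds were tested in a functional assay on IGROV-1 cells (Homo sapiens) for inhibition, read by sulforhodamine B assay, with a stated time of 48 h, tested at 10 uM; a higher number here means more inhibition at the concentration tested (going by the name of the read-out), a lower number less inhibition. Compound 1, with a bromo group on the shared core, gives 6.6%. Compound 2, which carries a thiophen-3-yl group at the same place, gives 1.51%. Among the two numbers compound 2 has the lower one, but the only step measured, a number 5.1 percentage points lower from compound 1 to compound 2 (within the scatter), is within the scatter, so the two compounds cannot be told apart on these data.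

The next compound, compound 3, `Brc1ccc(-c2cn3ccnc3c(-c3ccc4ncn(C5CCCCC5)c4c3)n2)cc1`, differs from compound 2 in one place: 4-bromophenyl in place of thiophen-3-yl on an aromatic carbon.

Among the compounds with values here, the one step that bears on this change is the one from compound 1 to compound 2, where a small bromo group was replaced by thiophen-3-yl at this very position, and the read-out in this assay barely moved. Within the data shown here, with only that step to go on, a change from one aromatic ring to another aromatic ring at the same place is expected to give a step of about a number 3.5 percentage points higher from compound 2 to compound 3 (within the scatter), that is, nothing beyond the scatter. Compound 3 is therefore estimated at 5%, with a range from -8% to 20%.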

Compound 3, a percentage reported as inhibition, at one concentration (the size of the read-out at that concentration, not a potency): 9.4%
The estimate for compound 3 lay 4.4 percentage points below the measured number; measured number inside the range.
By their numbers in this assay, from the lowest: compounds 2, 1 and 3 (each within the scatter of the next).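

With compound 3, this position on the shared core has carried three different groups, and in this assay their numbers still cannot be told apart: exchanging one aromatic ring for the other gives a number 7.9 percentage points higher from compound 2 to compound 3 (within the scatter), and exchanging bromo for the larger 4-bromophenyl gives a number 2.8 percentage points higher from compound 1 to compound 3 (within the scatter). Across these three compounds, then, neither replacing a five-membered aromatic ring containing sulfur with a six-membered all-carbon aromatic ring nor placing the bromine on a phenyl ring instead of directly on the core produces a step beyond the scatter. No supporting measurement is available to explain these numbers.

On these data alone, all three groups here lack a hydrogen-bond donor and carry no net charge, so it remains open whether an amine, a carboxylic acid or a longer alkyl chain at this position would give a step beyond the scatter. Because each number comes from a single concentration, these compounds also leave open how their potencies compare.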